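Replacing the imidazolyl group of compound 2

The compounds below may be only part of what the source reports. "The series", "measured", "known", "first", "only" and "open" are said of these compounds alone.

Measured in a functional assay on RKO cells (Homo sapiens) for antiproliferative activity, read by MTT assay, with a stated time of 5 days; on this read-out lower numbers stand for stronger inhibition and higher numbers for weaker inhibition:
Compound 1 `COc1cc[nH]c1/C=C1\C(=O)Nc2ccc([N+](=O)[O-])cc21`: 692 nM
Compound 2 `COc1cc[nH]c1/C=C1\C(=O)Nc2ccc([N+](=O)[O-])c(-n3ccnc3)c21`: 3920 nM
Compound 3 `COc1cc[nH]c1/C=C1\C(=O)Nc2ccc(F)cc21`: 11900 nM

Compound 2 holds the middle place of these three numbers, with compound 1 lower and compound 3 higher. Compound 4 `COc1cc[nH]c1/C=C1\C(=O)Nc2ccc([N+](=O)[O-])c(N[C@H]3CC[C@H](O)C3)c21` keeps the nitro group and the shared core of compound 2 but exchanges one group: (3-hydroxycyclopentyl)amino in place of 1H-imidazol-1-yl on an aromatic carbon. Within the data shown here, two measured steps bear on this. Adding 1H-imidazol-1-yl in place of hydrogen gave a 5.7-fold higher number from compound 1 to compound 2 (0.75 log units; beyond the scatter). Placing fluoro where nitro stood gave a 17-fold higher number from compound 1 to compound 3 (1.24 log units; beyond the scatter), but the nitro group stays here, so that large step sets no size for this exchange. Among the measured compounds shown here, no measured compound carries an amino group at this place, so the expectation is loose: a modest step toward a lower number, part of the way back. The expected change is a 2.2-fold lower number from compound 2 to compound 4 (0.34 log units; beyond the scatter). For compound 4 the estimated value is 1800 nM, within an expected range of 400 nM to 8000 nM.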

Compound 4, half-maximal inhibitory concentration: 339 nM
The estimate for compound 4 lay 5.3-fold (0.73 log units) above the measured number, and the stated range ends above it.
By their numbers in this assay, from the lowest: compound 4; then compound 1; then compound 2; then compound 3.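

On an aromatic carbon ortho to a nitro group, a substituent need not weaken the effect in this assay: (3-hydroxycyclopentyl)amino in place of hydrogen gave a 2.0-fold lower number from compound 1 to compound 4 (0.31 log units; beyond the scatter) even though 1H-imidazol-1-yl at this place had raised the number. Exchanging one group for the other gave a 12-fold lower number from compound 2 to compound 4 (1.06 log units; beyond the scatter) so what counts here is which group sits at this place, not only whether one does. Nothing shown explains why these two groups differ.

Which part of the new group matters stays open: a plain cyclopentylamino group without the hydroxyl, or a simple amine such as dimethylamino, would help separate the ring, the hydroxyl and the nitrogen. The compounds shown also do not tell whether the two defined stereocentres matter.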